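A few compounds are considered here, and "the series" means these few. Any claim that something is new, unique, unknown or untested is made for them only; others in the source may bear on it.

Measured so far in an assay on isolated protein for inhibition of Dihydrofolate reductase (Homo sapiens), read by spectrophotometry, using NADPH, with stated times of 5 s and 6 min, tested at 5 uM; a lower number here means a weaker effect, a higher number a stronger effect of the compound at the concentration tested:

compound 1, `NC1=NC2(CCSCC2)N(OCCCOc2cccc(Cl)c2)C(N)=N1`: 88.3%
compound 2, `NC1=NC2(CCSCC2)N(OCCCOc2cccc(Cl)c2Cl)C(N)=N1`: 83.8%
compound 3, `NC1=NC2(CCSCC2)N(OCCCOc2ccc(Br)cc2)C(N)=N1`: > 90%

The value of compound 3 is a limit of the assay, not a number; (the limit of > 90% in this assay, at which 1 of the 3 values shown sits). Compound 3 therefore stands at the top of the measured set, with only a floor for its inhibition.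

Among the measured steps, a number 4.5 percentage points lower from compound 1 to compound 2 (within the scatter), a number at least 1.7 percentage points higher from compound 1 to compound 3 (that floor lies within the scatter) and a number at least 6.2 percentage points higher from compound 2 to compound 3 (that floor lies within the scatter). All three change the substitution of the aromatic ring at the end of the three-carbon chain, and none of them is resolved beyond the scatter; what emerges is a series in which the ring substituent has so far moved the inhibition little at the tested concentration.

Compound 4, `COc1ccc(OCCCON2C(N)=NC(N)=NC23CCSCC3)cc1`, differs from compound 3 as follows: methoxy in place of bromo on an aromatic carbon. Within the data shown here, no measured step exchanges a halogen on this ring for an oxygen-bearing group, so the nearest guides are the three steps above, which bear only indirectly. Given that none of them exceeds the scatter, the expected change in this assay from compound 3 to compound 4 is a number at least 6 percentage points lower from compound 3 to compound 4 (that floor lies within the scatter), that is, none beyond the scatter. Compound 4 is accordingly estimated at 84%, with a range from 70% to 92%.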

Compound 4, a percentage reported as inhibition, at one concentration (the size of the read-out at that concentration, not a potency): 81.3%
Compound 4: middle estimate off by 2.7 percentage points, on the high side, and the stated range covers the measured number.
By their numbers in this assay, from the lowest: compounds 4, 2 and 1 (each within the scatter of the next). At a limit, above all of these: compound 3.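

In this assay, this is the only exchange shown of a halogen for an oxygen-bearing group on this ring: methoxy in place of bromo on an aromatic carbon, para to a large group, gives a number at least 8.7 percentage points lower from compound 3 to compound 4 (that floor lies within the scatter). Compound 3 gives > 90%, which is a limit of the assay and not a number, so this step has a floor but no size: the limit of > 90% in this assay, at which 1 of the 4 values shown sits. Set against the 2,3-dichlorophenyl and 3-chlorophenyl rings, the 4-methoxyphenyl ring gives a number 2.5 percentage points lower from compound 2 to compound 4 (within the scatter) and a number 7 percentage points lower from compound 1 to compound 4 (within the scatter), so the series now holds a ring without halogen and no step to it is printed as beyond the scatter.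

With a read-out at one concentration, these compounds do not separate the ring substituents from one another, and their potency remains unresolved. Still open, going by these compounds, is whether an amine or a carboxylic acid on this ring, or a longer chain in place of the one carrying the ring, would move the inhibition beyond the scatter.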